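The compounds below may be only part of what the source reports. "The series", "measured", "known", "first", "only" and "open" are said of these compounds alone.

Working notes on the series.

The first compound, compound 1 `CC(=O)Nc1ccc2oc(-c3ccccc3)cc(=O)c2c1`, was examined in an ADME assay on MT4 cells (Homo sapiens) for cytotoxicity, read by MTT assay, with a stated time of 4 days (a higher number here means that more compound is tolerated, a lower number that less compound is tolerated), where compound 1 gives 184000 nM. Compound 2 `COc1ccccc1-c1cc(=O)c2cc(NC(C)=O)ccc2o1` carries one extra group on the same core; the difference is methoxy in place of hydrogen on an aromatic carbon. In this assay compound 2 gives 226000 nM, and the step is a 1.2-fold higher number from compound 1 to compound 2 (0.09 log units; within the scatter).

Compound 3 `COc1c(-c2ccccc2)oc2ccc(N)cc2c1=O` is built on a different core; the difference between the core of compound 3 and the core of compound 1 is not broken down here. In this assay compound 3 gives 126000 nM. Its nearest neighbour among the measured numbers is compound 1 and its furthest is compound 2, but both gaps lie within the scatter, so no ordering among compounds 1, 2 and 3 can be read from these three values.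

Compound 4 `COc1ccccc1-c1oc2ccc(N)cc2c(=O)c1OC` has not yet been measured. It differs from compound 3 by methoxy in place of hydrogen on an aromatic carbon. Going by the values given here, this is the same change as the one from compound 1 to compound 2: the leaving hydrogen, the entering methoxy and the place, on an aromatic carbon of a six-membered aromatic ring of carbon only and ortho to a large group, all match word for word. The change occurs twice among the compounds shown, once measured and once not.

Among the compounds with values here, the expectation for compound 4 rests on the single measured instance of the change, because the step of a 1.2-fold higher number from compound 1 to compound 2 (0.09 log units; within the scatter) stayed within the scatter, and on the starting point of compound 3 at 126000 nM. Within the data shown here, with only one precedent and a different core, a near-flat step is the most plausible expectation, with a wide band around it. The step from compound 3 to compound 4 is therefore estimated as a 1.2-fold higher number from compound 3 to compound 4 (0.06 log units; within the scatter), and compound 4 is expected to give about 145000 nM in this assay, with a plausible range from 70000 nM to 300000 nM.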

Compound 4, half-maximal cytotoxic concentration: 229000 nM
Compound 4: the middle estimate sits 1.6-fold (0.20 log units) below what was measured; measured number inside the range.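

In this assay, methoxy in place of hydrogen on an aromatic carbon, ortho to a large group, gives a 1.8-fold higher number from compound 3 to compound 4 (0.26 log units; within the scatter), so this step on the second core also stays inside the usual variation of the measurement. Set beside the earlier step, the new one shows no difference between the two cores: the same change on two cores in this assay, a 1.2-fold higher number (0.09 log units; within the scatter) from compound 1 to compound 2 and a 1.8-fold higher number (0.26 log units; within the scatter) from compound 3 to compound 4, 1.5-fold (0.17 log units) apart, within the scatter of two such steps. This shows that, for this one change, the two available cores give no measurable sign of behaving differently, but it does not show that the change shifts the tolerated concentration in either direction, that the two steps are truly equal, or that the result extends beyond these four compounds.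

The compounds shown leave open whether the same result would hold on a third core, since two pairs on two cores are a narrow base for any general statement about transfer. They also leave open whether a different group on the same aromatic carbon, such as ethoxy, an amine or a carboxylic acid, would give a step that stays as small as those seen with methoxy.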